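Removing a Methyl from Three Compounds Stuck at the Limit

The source may hold more compounds than are shown below. What is called first, only, known or untested is meant among the compounds shown, and "the series" means these compounds.

Of the compounds shown here, three built on one shared core have been tested in a functional assay on MOLT-3 cells (Homo sapiens) for cytotoxicity, read by MTT assay, with a stated time of 48 h; a higher number here means a weaker inhibitor, a lower number a stronger inhibitor. Compound 1 `COc1cc2c(cc1OC)CN(S(=O)(=O)c1ccc(-n3cc(COc4ccccc4C(C)=O)nn3)cc1)CC2` gives > 50 ug/mL, which is a limit of the assay rather than a number. Compound 2 `Cc1ccccc1OCc1cn(-c2ccc(S(=O)(=O)N3CCc4ccccc4C3)cc2)nn1` likewise gives > 50 ug/mL, a limit. Compound 3 `COc1cc2c(cc1OC)CN(S(=O)(=O)c1ccc(-n3cc(COc4ccc(C)cc4)nn3)cc1)CC2` gives > 50 ug/mL, again a limit. The step that the two limits leave unreadable from compound 1 to compound 3 cannot be read because the limit of > 50 ug/mL in this assay, at which 3 of the 3 values shown sit, marks where all three values rest. Compound 4 `COc1cc2c(cc1OC)CN(S(=O)(=O)c1ccc(-n3cc(COc4ccccc4)nn3)cc1)CC2` differs from compound 3 by hydrogen in place of methyl on an aromatic carbon. Going by the values given here, no measured step bears on this change with a readable size; every value so far sits at the same limit. The step that the limit leaves unreadable from compound 3 to compound 4 is therefore expected to be no change beyond the scatter. The estimate for compound 4 is 70 ug/mL, with a range from 30 ug/mL to 250 ug/mL.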

Compound 4, half-maximal inhibitory concentration: > 50 ug/mL
Compound 4 gave a limit, no number (the forecaster's own chance of this, stated with the estimate: 85%); the middle value is on the limit's open side.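

Compound 4 also gives only a limit, so its steps from compound 3 and from compound 1 cannot be read, because all the values rest at one limit: the limit of > 50 ug/mL in this assay, at which 4 of the 4 values shown sit.

On these data alone, how methyl, acetyl and hydrogen truly compare on this aromatic ring remains open.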